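A Methoxy Added to a Fluorinated Chalcone Core

The compounds below may be only part of what the source reports. "The series", "measured", "known", "first", "only" and "open" are said of these compounds alone.

Compound 1 `COc1cc(/C=C/C(=O)c2ccccc2F)cc(OC)c1` and compound 3 `COc1cc(/C=C/C(=O)c2ccc(OC)cc2F)cc(OC)c1` share one core, while compound 2 `COc1ccc(C(=O)/C=C/c2ccc(OC)cc2OC)c(F)c1` and compound 4 `COc1ccc(C(=O)/C=C/c2c(OC)cc(OC)cc2OC)c(F)c1` share another; the difference between the two cores is not broken down here. In a functional assay on HCT-15 cells (Homo sapiens) for cytotoxicity, read by MTT assay, with a stated time of 72 h (on this read-out lower numbers stand for stronger inhibition and higher numbers for weaker inhibition), compound 1 gives 20.9 nM, and compound 3 gives 55.3 nM. The change from compound 1 to compound 3 is methoxy in place of hydrogen on an aromatic carbon and it brought a 2.6-fold higher number from compound 1 to compound 3 (0.42 log units; beyond the scatter). In this assay compound 2 gives 72.2 nM, a number that lies within the usual scatter of the value of compound 3.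

The change from compound 2 to compound 4 is methoxy in place of hydrogen on an aromatic carbon It is the same kind of change as that from compound 1 to compound 3, but the surroundings differ: in compound 3 the entering methoxy stands meta to a fluoro group and para to a large group, whereas in compound 4 it stands ortho to a large group and meta to two methoxy groups. Because a 2.6-fold higher number from compound 1 to compound 3 (0.42 log units; beyond the scatter) was a modest weakening, the step from compound 2 to compound 4 is expected to be of similar modest size, a 2.5-fold higher number from compound 2 to compound 4 (0.40 log units; beyond the scatter). Compound 4 is therefore estimated at 180 nM, with a likely range from 70 nM to 500 nM.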

Compound 4, half-maximal inhibitory concentration: > 100000 nM
Compound 4 gave a limit, no number; the forecaster's own chance of this, stated with the estimate: 3%; at least 550-fold (2.74 log units) between middle value and limit.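

Going by the step of an at least 1300-fold higher number from compound 2 to compound 4 (3.14 log units; beyond the scatter), methoxy in place of hydrogen on an aromatic carbon did not carry the size of its effect from one core to the other in this assay: the same change on two cores in this assay, a 2.6-fold higher number (0.42 log units; beyond the scatter) from compound 1 to compound 3 and an at least 1300-fold higher number (3.14 log units; beyond the scatter) from compound 2 to compound 4, at least 520-fold (2.71 log units) apart, beyond the scatter of two such steps

Compound 4 gives > 100000 nM, which is a limit of the assay and not a number: the limit of > 100000 nM in this assay, at which 1 of the 4 values shown sits.

The comparison shows that the step on the core of compound 1 was no guide to the step on the core of compound 2, but it does not show why the two differ, it gives only a lower bound for the larger step, and two pairs yield no rule for other cores.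

The compounds shown leave open whether the sharp loss belongs to the methoxy as such or to its place, ortho to a large group and meta to two methoxy groups. They also leave open whether a hydroxy group or an amine at that same place would give a measurable number in this assay.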